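The source may report more compounds than this note shows. Statements on the series, on what has been measured and on what is new or still open speak of the compounds shown alone.

Compound 3 `Cn1nc2c(=O)n(CC3(O)CCN(Cc4ccc(-c5ccco5)cc4Cl)CC3)cnc2c1-c1ccc(CNC(=O)C(F)(F)F)cc1` stands at the top of the three numbers in hand: in an assay on isolated protein for inhibition of ubiquitin carboxyl-terminal hydrolase 7 (Homo sapiens), with stated times of 30 min and 2 h (a higher number here means a weaker inhibitor, a lower number a stronger inhibitor), compound 3 gives 2060 nM. Its nearest neighbour is compound 1 `Cn1nc2c(=O)n(CC3(O)CCN(Cc4ccc(-c5ccco5)cc4Cl)CC3)cnc2c1-c1ccc(C(F)(F)F)cc1`, which in this assay gives 530 nM, and the far end is compound 2 `CCNCc1ccc(-c2c3ncn(CC4(O)CCN(Cc5ccc(-c6ccco6)cc5Cl)CC4)c(=O)c3nn2C)cc1`, which gives 15.2 nM. The step from compound 3 to compound 4 `Cn1nc2c(=O)n(CC3(O)CCN(Cc4ccc(-c5ccco5)cc4Cl)CC3)cnc2c1-c1ccc(Cl)cc1` is chloro in place of (((trifluoromethyl)carbonyl)amino)methyl on an aromatic carbon.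

Two measured steps speak to this change, since both also alter the group on that same aromatic carbon. Going from the trifluoromethyl of compound 1 to the larger amide-bearing group of compound 3 brought a 3.9-fold higher number from compound 1 to compound 3 (0.59 log units; beyond the scatter), and swapping the ethyl on the amine nitrogen for a (trifluoromethyl)carbonyl gave a 140-fold higher number from compound 2 to compound 3 (2.13 log units; beyond the scatter). Compound 4 replaces the whole amide-bearing group with a single chloro, a small substituent with no donor and no acceptor, much as the trifluoromethyl of compound 1 is. Compound 4 is therefore expected to return toward compound 1 rather than toward compound 2, a step of a 3.4-fold lower number from compound 3 to compound 4 (0.54 log units; beyond the scatter) in this assay. The estimate for compound 4 in this assay is 600 nM, with a range from 200 nM to 1800 nM.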

Compound 4, half-maximal inhibitory concentration: 143 nM
For compound 4 the middle estimate is 4.2-fold (0.62 log units) above the measured one; the measured number lies below the stated range.
By their numbers in this assay, from the lowest: compound 2; then compound 4; then compound 1; then compound 3.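

In this assay this position responds even to an exchange between two groups without nitrogen: chloro in place of trifluoromethyl gives a 3.7-fold lower number from compound 1 to compound 4 (0.57 log units; beyond the scatter) and so places compound 4 ahead of compound 1. Replacing the (((trifluoromethyl)carbonyl)amino)methyl group with chloro gives a 14-fold lower number from compound 3 to compound 4 (1.16 log units; beyond the scatter). This step is larger than the one between compound 1 and compound 3, so the penalty carried by that amide-bearing group exceeds what the trifluoromethyl comparison alone had shown. Chloro does not match the (ethylamino)methyl group, with a 9.4-fold higher number from compound 2 to compound 4 (0.97 log units; beyond the scatter) remaining as a gap, so among these four compounds a single chlorine reaches the second-lowest number while the amine-bearing compound 2 keeps the lowest.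

No measurement available here accounts for this order among the four groups. Still open, from the compounds shown here alone, is how bromo, fluoro or methyl would compare with chloro at this position, and whether a primary aminomethyl group or a longer aminoalkyl chain would go beyond the (ethylamino)methyl group of compound 2.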